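A few compounds are considered here, and "the series" means these few. Any claim that something is new, unique, unknown or untested is made for them only; others in the source may bear on it.

Measured compounds:
compound 1 `Cc1ccc(-c2nc(N)c3cc(Cc4ccccc4Cl)sc3n2)o1`, 26.1 nM in a functional assay on CHO-K1 cells for antagonist activity at adenosine receptor A1 (Homo sapiens), read by a beta-galactosidase reporter and cAMP accumulation, with stated times of 15 min and 6 h; on this read-out lower numbers stand for stronger inhibition and higher numbers for weaker inhibition
compound 3 `N#Cc1cccc(-c2nc(N)c3cc(Cc4ccccc4Cl)sc3n2)c1`, 24.8 nM in this assay
For compound 2 `Cc1ccc(-c2nc(N)c3cc(Cc4ccccc4F)sc3n2)o1` this assay reports only a limit, < 16 nM.

Compound 1 and compound 2 differ in one place, (fluoro in place of chloro on an aromatic carbon), and this change gave an at least 1.6-fold lower number from compound 1 to compound 2 (0.21 log units; that floor lies within the scatter). The value of compound 2 sits at the limit of < 16 nM in this assay, at which 1 of the 3 values shown sits, so the true size of that step is not known. Compound 1 and compound 3 differ in their cores, (3-cyanophenyl in place of 5-methylfuran-2-yl on an aromatic carbon), and that gave a 1.1-fold lower number from compound 1 to compound 3 (0.02 log units; within the scatter).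

Compound 4 `N#Cc1cccc(-c2nc(N)c3cc(Cc4ccccc4F)sc3n2)c1` has not yet been measured in this assay. It differs from compound 3 by fluoro in place of chloro on an aromatic carbon, the same change that turns compound 1 into compound 2, at the same kind of place. For compound 4 the step of a 1.7-fold lower number from compound 3 to compound 4 (0.22 log units; within the scatter) is expected, resting on an at least 1.6-fold lower number from compound 1 to compound 2 (0.21 log units; that floor lies within the scatter). Compound 4 is therefore estimated at 15 nM in this assay, expected to lie between 7 nM and 30 nM.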

Compound 4, inhibition constant: < 16 nM
Compound 4 gave a limit, no number; the forecaster's own chance of this, stated with the estimate: 45%; the middle value does not contradict the limit.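

In this assay compound 4 gives only a limit, < 16 nM. Fluoro in place of chloro gave an at least 1.5-fold lower number from compound 3 to compound 4 (0.19 log units; that floor lies within the scatter), and beside the same change on the other core the two steps can be compared only as floors: the same change on two cores in this assay, an at least 1.6-fold lower number (0.21 log units; that floor lies within the scatter) from compound 1 to compound 2 and an at least 1.5-fold lower number (0.19 log units; that floor lies within the scatter) from compound 3 to compound 4; the limit leaves it open whether they differ So nothing shows the change behaving differently on the two cores, yet equal size is not shown either, and the step between the two fluoro compounds cannot be read: the limit of < 16 nM in this assay, at which 2 of the 4 values shown sit.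

The compounds shown leave open what true numbers lie behind the two limits. They also leave open what a bromo, methyl or methoxy group would give at the same place on either core.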